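This account rests on a few compounds, and the source may have more. Where it says the series, first, only, none or still open, it means among the compounds named here.

Compound 1 `CC(C)(Oc1ccc(F)cc1)C1OCC(C/C=C\CCC(=O)O)C(c2cccnc2)O1`: 2000 nM
Compound 2 `Cc1ccc(OC(C)(C)C2OCC(C/C=C\CCC(=O)O)C(c3cccnc3)O2)cc1`: 25000 nM
Compound 3 `CC(C)(Oc1ccccc1F)C1OCC(C/C=C\CCC(=O)O)C(c2cccnc2)O1`: < 1000 nM

In an assay for inhibition of prostacyclin synthase (Homo sapiens), using microsomes (on this read-out lower numbers stand for stronger inhibition and higher numbers for weaker inhibition), compound 1 gives 2000 nM and compound 2 gives 25000 nM. For compound 3 the reported result < 1000 nM is a limit of the assay rather than a number, so its exact place among the shown values stays open (the limit of < 1000 nM in this assay, at which 1 of the 3 values shown sits). Compound 4 `COc1ccccc1OC(C)(C)C1OCC(C/C=C\CCC(=O)O)C(c2cccnc2)O1` differs from compound 3 by methoxy in place of fluoro on an aromatic carbon. Of the measured steps, the one that likewise replaced a fluoro by a carbon-bearing group, a 13-fold higher number from compound 1 to compound 2 (1.10 log units; beyond the scatter), was a clear loss, while an at least 25-fold lower number from compound 2 to compound 3 (1.39 log units; beyond the scatter) ran the other way. A loss of comparable size is therefore expected for the new step, an at least 4.0-fold higher number from compound 3 to compound 4 (0.60 log units; beyond the scatter). Compound 4 is estimated at 4000 nM, within a range from 800 nM to 20000 nM.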

Compound 4, half-maximal inhibitory concentration: 51000 nM
The estimate for compound 4 lay 13-fold (1.11 log units) below the measured number, and the stated range ends below it.
By their numbers in this assay, from the lowest: compound 1; then compound 2; then compound 4. At a limit, below all of these: compound 3.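

So the same spot on the ring that holds fluoro does not accept methoxy ortho to a large group, with an at least 51-fold higher number from compound 3 to compound 4 (1.70 log units; beyond the scatter). Compound 3 has only a limit of the assay, so that size is a floor: the limit of < 1000 nM in this assay, at which 1 of the 4 values shown sits.

Compound 4 is also weaker than both para-substituted compounds, with a 2.0-fold higher number from compound 2 to compound 4 (0.31 log units; beyond the scatter) and a 26-fold higher number from compound 1 to compound 4 (1.41 log units; beyond the scatter), so placing a group at this position does not by itself secure stronger inhibition.

On these data alone, whether the loss follows the added oxygen or the added carbon stays open. A hydroxy or a methyl at this same place would help separate the two.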